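This account rests on a few compounds, and the source may have more. Where it says the series, first, only, none or still open, it means among the compounds named here.

Compound 2 `Cc1ccccc1C#Cc1ccc2c(n1)CCN(C(C)C)C2=O` is the starting point. In an assay on HEK293 cells for displacement of a labelled ligand from metabotropic glutamate receptor 5 (Homo sapiens), with a stated time of 2 h (a lower number here means a stronger inhibitor, a higher number a weaker inhibitor), compound 2 gives > 32000 nM, which is a limit of the assay rather than a number. Compound 1 `Cc1ccccc1C#Cc1ccc2c(n1)CCN(C)C2=O` differs from it only by a methyl instead of the isopropyl on the amide-type nitrogen in the ring; in this assay compound 1 gives > 32000 nM, again a limit. The step that the two limits leave unreadable from compound 1 to compound 2 therefore cannot be read, and the limit of > 32000 nM in this assay, at which 2 of the 2 values shown sit, is all the two values show. Compound 3 `CC(C)N1CCc2nc(C#Cc3ccc(Cl)cc3)ccc2C1=O` differs from compound 2 by 4-chlorophenyl in place of 2-methylphenyl on a triple-bonded carbon. For the measured compounds named here, no measured step touches this change, and the two limits give neither a direction nor a size for it, so no step beyond the scatter can be expected in this assay in either direction. On that footing compound 3 is estimated at 15000 nM, within 1500 nM to 150000 nM. The expected step of an at least 2.1-fold lower number from compound 2 to compound 3 (0.32 log units; beyond the scatter) is accordingly one that the data cannot support in any direction.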

Compound 3, inhibition constant: 27100 nM
The estimate for compound 3 lay 1.8-fold (0.26 log units) below the measured number, and the stated range covers the measured number.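

Changing the group on the triple-bonded carbon gives what neither earlier compound gave: in this assay compound 3 gives 27100 nM, a number and not a limit. The change from 2-methylphenyl to 4-chlorophenyl reads as an at least 1.1-fold lower number from compound 2 to compound 3 (0.07 log units; that floor lies within the scatter), so this position shows no step beyond the scatter, although that figure is only a floor and a larger step is not excluded. The step between the methyl and isopropyl compounds still cannot be read, and the other two values remain limits: the limit of > 32000 nM in this assay, at which 2 of the 3 values shown sit.

The compounds shown leave open how plain phenyl or a pyridine ring on the triple-bonded carbon would read in this assay. They also leave open whether 4-chlorophenyl would give a number with methyl in place of isopropyl on the amide-type nitrogen.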